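A few compounds are considered here, and "the series" means these few. Any claim that something is new, unique, unknown or untested is made for them only; others in the source may bear on it.

Working notes on the series. Of the compounds shown here, two have values so far, compound 1 `COc1ccc(/C=C/C(=O)C(=Cc2cc(Br)c(O)c(OC)c2)C(=O)/C=C/c2ccc(OC)cc2OC)c(OC)c1` and compound 2 `COc1cc(OC)c(/C=C/C(=O)C(=Cc2ccc(O)c(OC)c2)C(=O)/C=C/c2c(OC)cc(OC)cc2OC)c(OC)c1`. In a functional assay on SW480 cells (Homo sapiens) for antiproliferative activity, read by sulforhodamine B assay, with a stated time of 48 h (on this read-out higher numbers stand for weaker inhibition and lower numbers for stronger inhibition), compound 1 gives 1480 nM and compound 2 gives 1490 nM. These two numbers lie within the scatter of each other, so compound 2 stands level with compound 1, and neither can be ranked over the other.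

The next compound is compound 3 `COc1cc(OC)c(/C=C/C(=O)C(=Cc2ccc(O)c(F)c2)C(=O)/C=C/c2c(OC)cc(OC)cc2OC)c(OC)c1`, which carries fluoro in place of methoxy on an aromatic carbon, ortho to a hydroxy group: fluoro in place of methoxy on an aromatic carbon. The same change reads as 4-hydroxy-3-methoxyphenyl to 3-fluoro-4-hydroxyphenyl, and the hydroxy group itself stays.

Within the data shown here, no measured pair differs in one place only, so no measured step shows what a change of this kind does in this assay. Among the measured compounds shown here, the only guide is the level shared by the two measured compounds, so no step beyond the scatter is expected, in either direction, and the range is kept wide. The estimated step is a 1.0-fold higher number from compound 2 to compound 3 (0.00 log units; within the scatter). For compound 3 the expected value in this assay is 1500 nM, with an estimated range of 600 nM to 3700 nM.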

Compound 3, half-maximal inhibitory concentration: 1950 nM
Compound 3: the middle estimate sits 1.3-fold (0.11 log units) below what was measured, within the range that was stated.
By their numbers in this assay, from the lowest: compounds 1, 2 and 3 (each within the scatter of the next).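

Among these compounds, this is the first pair that differs in one place only, and in this assay the exchange of methoxy for fluoro on this aromatic carbon, ortho to a hydroxy group, gives a 1.3-fold higher number from compound 2 to compound 3 (0.12 log units; within the scatter) as its step. With the hydroxy group kept, methoxy and fluoro therefore cannot be told apart at this position on this read-out, and the methoxy group is not required to hold the level of compound 2. No measurement at hand speaks to why the two groups read alike.

As far as these compounds go, whether this tolerance extends to other groups on the same carbon, such as an amine, a chloro group or a longer alkoxy chain, stays open, as does the contribution of the hydroxy group, which is present in both compound 2 and compound 3. From the compounds shown here alone, compound 1 differs from compound 2 in more than one place, so the effect of its bromo group cannot be separated from the other differences, and the remaining parts of the core stay untested by any single-place comparison.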